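A few compounds are considered here, and "the series" means these few. Any claim that something is new, unique, unknown or untested is made for them only; others in the source may bear on it.

Measured compounds:
- Compound 1 `CNC(=O)CN1CCC(c2cc3c(-c4ccc(=O)n(C(C)C)c4)ccnc3[nH]2)CC1`: 2.2
- Compound 2 `CC(C)n1cc(-c2ccnc3[nH]c(C4CCN(CC(=O)N(C)C)CC4)cc23)cnc1=O`: 0.4
- Compound 3 `CC(C)n1cc(-c2ccnc3[nH]c(C4CCN(CC(=O)N5CCCCC5)CC4)cc23)ccc1=O`: 2.8

In a physicochemical assay for lipophilicity, using the shake flask method, measured as octanol-water partition, at pH 7.4 (a higher number here means a more lipophilic compound, a lower number a more polar compound), compound 1 gives 2.2 and stands second highest of the three values. Its nearest neighbour is compound 3, with the distribution coefficient sitting higher by a number 0.60 log units higher from compound 1 to compound 3 (beyond the scatter); compound 2 lies furthest away and reads lowest of the set.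

The unmeasured compound 4 `CC(C)n1cc(-c2ccnc3[nH]c(C4CCN(CC(=O)N(C)C)CC4)cc23)ccc1=O` is derived from compound 1 by a single change: methyl in place of hydrogen on an amide-type nitrogen. Within the data shown here, the only measured step that bears on this position is the one from compound 1 to compound 3, where a larger cyclic amine replaced the methylamino group and the distribution coefficient rose by a number 0.60 log units higher from compound 1 to compound 3 (beyond the scatter), a modest but real step. A single added methyl on the same amide nitrogen is a smaller change than that, so a smaller rise in this assay is expected, in the same direction. Compound 2 carries the same dimethylcarbamoyl group but differs elsewhere, so its low value gives no direct guidance for this step.

Compound 4 is therefore estimated at 2.5, within a range of 2.1 to 2.9, corresponding to an expected step of a number 0.30 log units higher from compound 1 to compound 4 (within the scatter).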

Compound 4, distribution coefficient: 1.9
Beside the measured number, compound 4's estimate is 0.60 log units above it; the whole stated range lies above it.
By their numbers in this assay, from the lowest: compound 2; then compounds 4 and 1 (each within the scatter of the next); then compound 3.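

In this assay, methyl in place of hydrogen on the amide-type nitrogen gives a step within the scatter (a number 0.30 log units lower from compound 1 to compound 4 (within the scatter)), so at this position the amide hydrogen can be replaced with no measurable shift in the read-out. The clear steps involving compound 4 lie in other changes: dimethylamino in place of piperidin-1-yl on the carbonyl carbon (a number 0.90 log units lower from compound 3 to compound 4 (beyond the scatter)), and the exchange of the group on the aromatic carbon (a number 1.50 log units higher from compound 2 to compound 4 (beyond the scatter)). Nothing available here accounts for any of these steps.

As far as these compounds go, it remains open whether a longer chain such as ethyl on the same nitrogen, or morpholin-4-yl on the carbonyl carbon, would stay within the scatter of compound 1 or move as far as piperidin-1-yl does. Also open, from the compounds shown here alone, is whether the methyl step would read the same with the group carried by compound 2.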